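From a vinyl group to a piperidine ring

The source may report more compounds than this note shows. Statements on the series, on what has been measured and on what is new or still open speak of the compounds shown alone.

Compound 2 `C=Cc1nc(-c2c[nH]c3ccccc23)co1` carries a vinyl group on the five-membered ring of its shared core. Among the compounds with values here, in a functional assay on DU-145 cells (Homo sapiens) for cytotoxicity, read by MTT assay, with a stated time of 48 h (a higher number here means a weaker inhibitor, a lower number a stronger inhibitor), compound 2 gives 59800 nM, the lowest of the two numbers measured so far. Within the data shown here, its only neighbour, compound 1 `Cc1nc(-c2c[nH]c3ccccc23)co1`, gives 244000 nM in this assay, and the step of a 4.1-fold lower number from compound 1 to compound 2 (0.61 log units; beyond the scatter) is the single recorded change. Compound 3 `c1ccc2c(-c3coc(C4CCNCC4)n3)c[nH]c2c1` differs from compound 2 by piperidin-4-yl in place of vinyl on an aromatic carbon. Among the measured compounds shown here, no measured step replaces a short chain with a saturated ring of this kind, so the step from methyl to vinyl, although beyond the scatter, gives no direct guide. The step of a 1.5-fold lower number from compound 2 to compound 3 (0.17 log units; within the scatter) is therefore expected to be modest and could fall in either direction. Compound 3 is estimated at 40000 nM, with a wide range from 8000 nM to 200000 nM.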

Compound 3, half-maximal inhibitory concentration: 381000 nM
Beside the measured number, compound 3's estimate is 9.5-fold (0.98 log units) below it; the whole stated range lies below it.
By their numbers in this assay, from the lowest: compound 2; then compounds 1 and 3 (each within the scatter of the next).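

The gain seen with vinyl at this position on the five-membered aromatic ring does not carry over to every larger group: in this assay, placing piperidin-4-yl there in place of vinyl gives a 6.4-fold higher number from compound 2 to compound 3 (0.80 log units; beyond the scatter) and loses that gain. Set against methyl, the same ring gives a 1.6-fold higher number from compound 1 to compound 3 (0.19 log units; within the scatter), so these two groups cannot be told apart here, and vinyl is the only one of the three that stands apart from both others. Nothing measured here explains this difference.

The change from vinyl to piperidin-4-yl introduces a saturated ring and a ring nitrogen together, so the compounds shown cannot separate the part played by each. Going by these compounds, a cyclohexyl group, the same ring without the nitrogen, and a longer carbon chain such as propyl remain open at this position.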